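Removing the dimethylamino group from compound 3

The compounds below may be only part of what the source reports. "The series", "measured", "known", "first", "only" and "open" are said of these compounds alone.

Measured so far in a functional assay on KB cells (Homo sapiens) for inhibition (on this read-out higher numbers stand for weaker inhibition and lower numbers for stronger inhibition), are three compounds, each reported only as a limit:
- Compound 1 `OCC(CO)OCn1c(Cl)nc2c(Cl)c(Cl)ccc21` reads > 100000 nM as a limit.
- Compound 2 `CNc1nc2c(Cl)c(Cl)ccc2n1COC(CO)CO` reads > 100000 nM as a limit.
- Compound 3 `CN(C)c1nc2c(Cl)c(Cl)ccc2n1COC(CO)CO` reads > 100000 nM as a limit.

Compound 3 therefore has no exact number, and the whole set looks the same: the limit of > 100000 nM in this assay, at which 3 of the 3 values shown sit, is all that can be said so far.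

Compound 4 `OCC(CO)OCn1cnc2c(Cl)c(Cl)ccc21` differs from compound 3 in one place, with hydrogen in place of dimethylamino on an aromatic carbon between two ring nitrogen atoms.

For the measured compounds named here, three measured steps bear on this carbon: a step that the two limits leave unreadable from compound 1 to compound 2 and a step that the two limits leave unreadable from compound 1 to compound 3 and a step that the two limits leave unreadable from compound 2 to compound 3 all end in limits, so none offers a size to carry over. Hydrogen at this carbon has not yet been measured, which keeps the expectation loose.

The expected step is a number no higher from compound 3 to compound 4 (the limit leaves the size open) in this assay and no clear move beyond the scatter is foreseen. Compound 4 is estimated at 100000 nM with an expected range from 30000 nM to 300000 nM on this read-out.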

Compound 4, half-maximal inhibitory concentration: > 100000 nM
Compound 4 gave a limit, no number; the forecaster's own chance of this, stated with the estimate: 80%; the middle value sits exactly at the limit.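

Compound 4 reads > 100000 nM as a limit, so its steps from compound 1, compound 2 and compound 3 cannot be read. The compounds shown leave open whether any group at this carbon gives a measurable number in this assay, since all share one ceiling: the limit of > 100000 nM in this assay, at which 4 of the 4 values shown sit.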